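This account rests on a few compounds, and the source may have more. Where it says the series, first, only, none or still open, it means among the compounds named here.

Measured compounds:
compound 1 `COc1ccc(C(=O)CSc2nc(Cc3c(F)cccc3Cl)c(C)c(=O)[nH]2)cc1` — > 12000 nM
compound 2 `CCc1c(Cc2c(F)cccc2Cl)nc(SCC(=O)c2ccc(OC)cc2)[nH]c1=O` — > 11000 nM
compound 3 `Cc1c(Cc2c(F)cccc2F)nc(SCC(=O)c2ccccc2)[nH]c1=O` — 65000 nM

Compound 1 and compound 2 differ by methyl in place of hydrogen on a saturated chain carbon bound to an aromatic carbon. In an ADME assay on MT4 cells (Homo sapiens) for cytotoxicity, read by MTT assay (a higher number here means that more compound is tolerated, a lower number that less compound is tolerated), compound 1 gives > 12000 nM, which is a limit of the assay, not a number. Compound 2 gives > 11000 nM, likewise a limit. The step that the two limits leave unreadable from compound 1 to compound 2 therefore cannot be sized; the limit of > 12000 nM in this assay, at which 1 of the 3 values shown sits, and the limit of > 11000 nM in this assay, at which 1 of the 3 values shown sits, hide both ends of it. For the measured compounds named here, compound 3 is the only compound of the three with a numerical read-out, giving 65000 nM in this assay. How the core of compound 3 differs from the core of compound 1 is not broken down here.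

Compound 4 `CCc1c(Cc2c(F)cccc2F)nc(SCC(=O)c2ccccc2)[nH]c1=O` is not yet measured. It differs from compound 3 by methyl in place of hydrogen on a saturated chain carbon bound to an aromatic carbon, the same change as from compound 1 to compound 2. Since that earlier step is unreadable, the expectation for compound 4 rests on compound 3 alone, whose 65000 nM is taken as the anchor, with a step of a 1.1-fold lower number from compound 3 to compound 4 (0.03 log units; within the scatter) expected to stay within the usual scatter. Compound 4 is estimated at 60000 nM, between 25000 nM and 130000 nM.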

Compound 4, half-maximal cytotoxic concentration: 56000 nM
Compound 4: middle estimate off by 1.1-fold (0.03 log units), on the high side; low and high end bracket the measured number.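

In this assay, methyl in place of hydrogen on a saturated chain carbon bound to an aromatic carbon, which reads as methyl to ethyl, gives a 1.2-fold lower number from compound 3 to compound 4 (0.06 log units; within the scatter), so compound 3 and compound 4 cannot be told apart in this read-out. The same change on the core of compound 1 cannot be read, as both ends of that step are limits of the assay and not numbers. The result therefore rests on a single readable step on one core: it shows that the change is tolerated within the scatter there, but not that it carries over to another core.

Open, as far as these compounds go, is whether a longer chain such as propyl, or an amine or a carboxylic acid in the place of that ethyl, would stay within the scatter of compound 3 in this assay. Also open, from the compounds shown here alone, is the size of the step on the core of compound 1, which takes numbers at both ends to settle.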